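Aryl variation on a piperidinylethyl pyrazolopyrimidine sigma-1 series

The source may report more compounds than this note shows. Statements on the series, on what has been measured and on what is new or still open speak of the compounds shown alone.

Measured so far:
compound 1 `Clc1ccccc1-c1ncnc2c1cnn2CCN1CCCCC1` 76 nM
compound 2 `Cc1ccc(C)c(-c2ncnc3c2cnn3CCN2CCCCC2)c1` 63 nM

In an assay on HEK293 cells for displacement of a labelled ligand from Sigma non-opioid intracellular receptor 1 (Homo sapiens), read by scintillation counting, with a stated time of 120 min (on this read-out higher numbers stand for weaker inhibition and lower numbers for stronger inhibition), compound 2 gives the lower of the two numbers, yet its neighbour compound 1 sits within the scatter of it, as the step of a 1.2-fold lower number from compound 1 to compound 2 (0.08 log units; within the scatter) shows. Compound 3 `Fc1cc(Cl)ccc1-c1ncnc2c1cnn2CCN1CCCCC1` is the next step: 4-chloro-2-fluorophenyl in place of 2,5-dimethylphenyl on an aromatic carbon. For the measured compounds named here, only the step from compound 1 to compound 2 bears on an aryl exchange here, and it stayed within the scatter, so no shift beyond the scatter is expected in this assay for compound 3, estimated as a 1.1-fold higher number from compound 2 to compound 3 (0.05 log units; within the scatter). The expected value for compound 3 is 70 nM, with a range of 30 nM to 170 nM.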

Compound 3, inhibition constant: 112 nM
The estimate for compound 3 lay 1.6-fold (0.20 log units) below the measured number, within the range that was stated.
By their numbers in this assay, from the lowest: compounds 2, 1 and 3 (each within the scatter of the next).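

In this assay the steps of a 1.8-fold higher number from compound 2 to compound 3 (0.25 log units; within the scatter) and a 1.5-fold higher number from compound 1 to compound 3 (0.17 log units; within the scatter) both lie within the scatter. This position on the shared core thus carries 4-chloro-2-fluorophenyl, 2-chlorophenyl and 2,5-dimethylphenyl with no step beyond the scatter, so a ring bearing both fluorine and chlorine reads the same as one bearing chlorine alone or two methyl groups. No evidence here bears on the reason for these numbers.

Open, as far as these compounds go, is whether a non-phenyl group at this position, such as a pyridine ring, a cyclohexyl ring or an amine, would give a step beyond the scatter. Also open, from the compounds shown here alone, is what a longer chain to the piperidine would do.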